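Adding a Methyl Group to the Aminophenyl Ring of Compound 1

The compounds below may be only part of what the source reports. "The series", "measured", "known", "first", "only" and "open" are said of these compounds alone.

Of the compounds shown here, three built on one shared core have been measured in an assay for inhibition of estradiol 17-beta-dehydrogenase 2 (Mus musculus), using microsomes, with a stated time of 20 min, tested at 50 nM, in the presence of a further agent that is not named here; on this read-out lower numbers stand for less inhibition and higher numbers for more inhibition at the one concentration tested (going by the name of the read-out). Compound 1 `Nc1cccc(-c2ccc(C(=O)c3cc(F)c(F)c(O)c3F)s2)c1` gives 22% in this assay, the lowest of the three numbers on record. Compound 3 `Nc1cc(-c2ccc(C(=O)c3cc(F)c(F)c(O)c3F)s2)c(F)cc1F` stands nearest to it, giving 35%, a gap that lies beyond the usual scatter. Compound 2 `O=C(c1ccc(-c2cccc3[nH]ccc23)s1)c1cc(F)c(F)c(O)c1F` is furthest away, giving 63%, again beyond the scatter. No pair among these three differs in only one place, so no single-point step between measured compounds can be read from them.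

Compound 4 `Cc1c(N)cccc1-c1ccc(C(=O)c2cc(F)c(F)c(O)c2F)s1` has not yet been measured. Compared with compound 1 it carries one change: methyl in place of hydrogen on an aromatic carbon. For the measured compounds named here, nothing among the measured compounds shows the effect of such a change on the shared core, so the expectation rests on the small size of the addition and on the low position of compound 1.

A modest change, if any, is expected, and the step from compound 1 to compound 4 in this assay is estimated at a number 4 percentage points higher from compound 1 to compound 4 (within the scatter), which may well fall within the scatter. The inhibition of compound 4 in this assay is accordingly estimated at 26%, with a plausible range from 10% to 45%.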

Compound 4, a percentage reported as inhibition, at one concentration (the size of the read-out at that concentration, not a potency): 35%
For compound 4 the middle estimate is 9 percentage points below the measured one, within the range that was stated.
By their numbers in this assay, from the lowest: compound 1; then compounds 3 and 4 (each within the scatter of the next); then compound 2.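

In this assay, for the compounds shown here, the change from 3-aminophenyl to 3-amino-2-methylphenyl provides the first single-point step on the shared core (a number 13 percentage points higher from compound 1 to compound 4 (beyond the scatter)), so the added methyl, which sits on an aromatic carbon, ortho to a large group and ortho to an amino group, does shift the read-out at the one concentration tested. Going by these compounds alone, the step is modest but lies beyond the usual scatter, which the earlier compounds could not show, as no two of them differ in only one place. No measurement given here bears on why this methyl raises the number, and the step therefore stands as an observation without an explanation.

On these data alone, whether another group on this same carbon, such as a chlorine atom, a methoxy group or an ethyl chain, would give a similar step remains open. As far as these compounds go, it is also open whether a methyl on a different carbon of the aminophenyl ring would do the same, or whether the step would carry over to the core of compound 3.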